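A Second Chloro on the Shared Core

The source may hold more compounds than are shown below. What is called first, only, known or untested is meant among the compounds shown, and "the series" means these compounds.

Measured compounds:
Compound 1, `ClCc1ccc(Cn2cnc3nc(Cl)nc(Cl)c32)cc1`: 13200 nM in a functional assay on SW-620 cells (Homo sapiens) for cytotoxicity, read by sulforhodamine B assay, with a stated time of 48 h; on this read-out lower numbers stand for stronger inhibition of growth and higher numbers for weaker inhibition of growth
Compound 2, `ClCc1ccccc1Cn1cnc2ncnc(Cl)c21`: 2230 nM in this assay

Of these two numbers compound 2 holds the lowest; compound 1 shows the higher one, and the gap lies beyond the scatter. Within the data shown here, the two differ in more than one place, so no single step links them. Compound 3, `ClCc1ccccc1Cn1cnc2nc(Cl)nc(Cl)c21`, differs from compound 2 by one change: chloro in place of hydrogen on an aromatic carbon. Among the measured compounds shown here, no measured step of this kind exists here, so the direction is uncertain. A modest weakening is expected, a 1.8-fold higher number from compound 2 to compound 3 (0.25 log units; within the scatter). Compound 3 is estimated at 4000 nM, within a range from 1200 nM to 15000 nM.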

Compound 3, concentration for 50% growth inhibition: 260 nM
For compound 3 the middle estimate is 15-fold (1.19 log units) above the measured one, outside the stated range (below it).
By their numbers in this assay, from the lowest: compound 3; then compound 2; then compound 1.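

In this assay, chloro in place of hydrogen on the aromatic carbon between two ring nitrogen atoms gives an 8.6-fold lower number from compound 2 to compound 3 (0.93 log units; beyond the scatter). Among these compounds, this is the first single change that can be read here, and it shows that this position affects growth inhibition, with chloro giving the stronger result of the two groups seen there. Nothing shown explains this gain. On these data alone, whether fluoro, a methoxy group or an amine on this carbon would match chloro remains open. One step also cannot show whether the gain would carry over to other compounds.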